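The source may hold more compounds than are shown below. What is called first, only, known or untested is meant among the compounds shown, and "the series" means these compounds.

Measured compounds in a functional assay on SK-OV-3 cells (Homo sapiens) for cytotoxicity; a higher number here means a weaker inhibitor, a lower number a stronger inhibitor:

- compound 1 `CN(C)c1ccc(-c2ccc3nc(CCCCCCC(=O)NO)[nH]c3c2)cc1`; compound 1 gives 6600 nM
- compound 2 `COc1ccc(-c2ccc3nc(CCCCCCC(=O)NO)[nH]c3c2)cc1`; compound 2 gives 3100 nM
- compound 3 `COc1ccc2nc(CCCCCCC(=O)NO)[nH]c2c1`; compound 3 gives 11000 nM

Within the measured set the only step that repeats is the one marked (dimethylamino in place of methoxy on an aromatic carbon), which in this assay gave a 2.1-fold higher number from compound 2 to compound 1 (0.33 log units; beyond the scatter). The cores of compound 2 and compound 3 differ by methoxy in place of 4-methoxyphenyl on an aromatic carbon, and that step read a 3.5-fold higher number from compound 2 to compound 3 (0.55 log units; beyond the scatter). Compound 1 and compound 3 are within the scatter of one another, as a 1.7-fold higher number from compound 1 to compound 3 (0.22 log units; within the scatter) shows.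

Compound 4 `CN(C)c1ccc2nc(CCCCCCC(=O)NO)[nH]c2c1` is not yet measured. It differs from compound 3 by dimethylamino in place of methoxy on an aromatic carbon. Among the measured compounds shown here, this is the same kind of change as the one from compound 2 to compound 1, not the same: in the measured pair the place is on an aromatic carbon of a six-membered aromatic ring of carbon only, para to a large group, whereas here it is on a ring that is part of a fused or bridged system of two rings, meta to a fused ring and para to a fused ring.

For the measured compounds named here, the expected step is a 2.0-fold higher number from compound 3 to compound 4 (0.30 log units; within the scatter), resting on the single measured precedent a 2.1-fold higher number from compound 2 to compound 1 (0.33 log units; beyond the scatter) applied to compound 3 at 11000 nM; with only one precedent, at a different place, the range is kept wide. Compound 4 is thus estimated at 22000 nM, between 8000 nM and 60000 nM.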

Compound 4, half-maximal inhibitory concentration: 1200 nM
For compound 4 the middle estimate is 18-fold (1.26 log units) above the measured one, and the stated range ends above it.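

In this assay the change from methoxy to dimethylamino does not carry from one core to the other, and its direction reverses between the two cores: the same change on two cores in this assay, a 2.1-fold higher number (0.33 log units; beyond the scatter) from compound 2 to compound 1 and a 9.2-fold lower number (0.96 log units; beyond the scatter) from compound 3 to compound 4, 20-fold (1.29 log units) apart, beyond the scatter of two such steps

On the smaller core the change gives a 9.2-fold lower number from compound 3 to compound 4 (0.96 log units; beyond the scatter), and compound 4 also reads lower than both compounds carrying a substituted phenyl group, with a 2.6-fold lower number from compound 2 to compound 4 (0.41 log units; beyond the scatter) and a 5.5-fold lower number from compound 1 to compound 4 (0.74 log units; beyond the scatter), so compound 4 is the strongest inhibitor of the four in this assay. This rests on one pair per core, and the two pairs differ both in the surrounding core and in the place of the change, so the data show that the step depends on its setting here but not which of these differences governs it.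

Going by these compounds, whether the low number of compound 4 is particular to dimethylamino remains open, as diethylamino or a primary amine at the same place could read differently. Among the compounds shown here, it is also open whether the result holds with a shorter or longer chain than the one shared by these compounds.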